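The source may report more compounds than this note shows. Statements on the series, on what has been measured and on what is new or still open speak of the compounds shown alone.

Measured so far in a physicochemical assay for lipophilicity, using the shake flask method, at pH 7.4; a lower number here means a more polar compound, a higher number a more lipophilic compound:

- Compound 1 `CCCC(Oc1ccc(-n2cc3ccccc3n2)cc1)c1ccc(C(=O)NCCC(=O)O)cc1`: 2.5
- Compound 2 `CCCC(Oc1ccc(-n2cc(C#N)cn2)cc1)c1ccc(C(=O)NCCC(=O)O)cc1`: 1.2
- Compound 3 `CCCC(Oc1ccc(-n2cccn2)cc1)c1ccc(C(=O)NCCC(=O)O)cc1`: 1.7

Among these three, compound 3 stands second highest at 1.7, above compound 2 and below compound 1. The next compound to be measured is compound 4 `CCCC(Oc1ccc(-n2cc(Cl)cn2)cc1)c1ccc(C(=O)NCCC(=O)O)cc1`. It carries chloro in place of hydrogen on an aromatic carbon of a five-membered aromatic ring with 2 nitrogen: chloro in place of hydrogen on an aromatic carbon. The closest evidence is a change at this same carbon, a number 0.50 log units higher from compound 2 to compound 3 (beyond the scatter), a modest step beyond the scatter. It involves cyano rather than chloro, so it shows how far a swap at this place can move the number but does not fix the direction. A second modest step, a number 0.80 log units lower from compound 1 to compound 3 (beyond the scatter), also concerns this ring, while a number 1.30 log units lower from compound 1 to compound 2 (beyond the scatter) is large. On this limited evidence, a modest rise in this assay is expected. The expected step is a number 0.50 log units higher from compound 3 to compound 4 (beyond the scatter). For compound 4 the estimated value is 2.2, with an expected range from 1.9 to 2.5.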

Compound 4, distribution coefficient: 2.6
Estimate against measurement, compound 4: 0.40 log units below, outside the stated range (above it).
By their numbers in this assay, from the lowest: compound 2; then compound 3; then compounds 1 and 4 (each within the scatter of the next).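

In this assay, among the compounds shown here, the earlier compounds compared only hydrogen and cyano on this aromatic carbon of the five-membered ring. Chloro now gives a number 0.90 log units higher from compound 3 to compound 4 (beyond the scatter) and, against cyano, a number 1.40 log units higher from compound 2 to compound 4 (beyond the scatter), so the two groups leave the number on opposite sides of the hydrogen compound, and one swap at this carbon can cover a large part of the range seen so far. Replacing the whole 2H-indazol-2-yl group with 4-chloro-1H-pyrazol-1-yl gives a number 0.10 log units higher from compound 1 to compound 4 (within the scatter), so a single chlorine atom on the 1H-pyrazol-1-yl group brings the number within the scatter of the compound with the larger group; no measurement here explains these shifts.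

As far as these compounds go, it remains open where a methyl, a methoxy or an amine at this carbon would fall. Whether fluoro or bromo would track chloro is also unsettled.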